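This account rests on a few compounds, and the source may have more. Where it says the series, first, only, none or still open, it means among the compounds named here.

Measured compounds:
- compound 1, `Cc1ccccc1-n1cc(-c2ccccc2)c(-c2ccc3c(c2)NC(=O)CO3)n1`: 54.2%
- compound 2, `O=C1COc2ccc(-c3nn(-c4ccc(F)cc4)cc3-c3ccccc3)cc2N1`: 92.6%

Both compounds were tested in a functional assay on MV4-11 cells (Homo sapiens) for cytotoxicity, read by colorimetric assay and MTT assay, with a stated time of 3 days, tested at 20 uM; on this read-out lower numbers stand for a stronger effect and higher numbers for a weaker effect at the one concentration tested. Compound 2 gives the highest of the two numbers, and on this read-out that means the weaker effect of the pair; the nearest number is that of compound 1, which lies beyond the usual scatter below it.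

Compound 3, `O=C1COc2ccc(-c3nn(-c4cc(Cl)cc(Cl)c4)cc3-c3ccccc3)cc2N1`, is not yet measured. It differs from compound 2 in one place: 3,5-dichlorophenyl in place of 4-fluorophenyl on an aromatic nitrogen.

Among the measured compounds shown here, only one measured step bears on this change. In it a different aryl group on the same aromatic nitrogen was exchanged, with a number 38.4 percentage points higher from compound 1 to compound 2 (beyond the scatter). That step shows that the group on this nitrogen can move the result by a large amount, but it does not show what a 3,5-dichlorophenyl group does. A step of some size is therefore expected in this assay, with the direction uncertain; a move back toward the number of compound 1 seems somewhat more likely than a further rise, since compound 2 already lies near the top of the scale.

Compound 3 is expected to give about 70%, within a range from 35% to 100%, which is an estimated a number 22.6 percentage points lower from compound 2 to compound 3 (beyond the scatter).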

Compound 3, a percentage reported as activity, at one concentration (the size of the read-out at that concentration, not a potency): 50.5%
Estimate against measurement, compound 3: 19.5 percentage points above; the measured number falls inside the stated range.
By their numbers in this assay, from the lowest: compounds 3 and 1 (each within the scatter of the next); then compound 2.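

The group on this aromatic nitrogen does more than switch the result between two fixed levels: in this assay, exchanging 4-fluorophenyl for 3,5-dichlorophenyl gives a number 42.1 percentage points lower from compound 2 to compound 3 (beyond the scatter) and so a much stronger effect at the one concentration tested. The high number of compound 2 is therefore not shared by every substituted phenyl group at this position. Comparing the two other aryl groups gives a number 3.7 percentage points lower from compound 1 to compound 3 (within the scatter) with no difference that can be told apart, so 2-methylphenyl and 3,5-dichlorophenyl behave alike here despite their different substituents, and among these three compounds only the 4-fluorophenyl group stands apart. No measurement available here explains why these aryl groups differ in this way.

As far as these compounds go, it remains open what a plain unsubstituted phenyl, a pyridine ring, or a non-aromatic group such as a morpholine-bearing chain would do on this nitrogen. The phenyl group and the shared core are the same in all three compounds, so the effect of a change there, such as adding an amine or a carboxylic acid, also stays unknown, as does how strong or weak the effect of any of these compounds would be at other concentrations.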